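Swapping hydroxy for bromo on the benzyl group

The source may report more compounds than this note shows. Statements on the series, on what has been measured and on what is new or still open speak of the compounds shown alone.

Compound 1 `CCCSc1nc(N/N=C(\C)c2ccccc2O)c2nnn(Cc3ccc(O)cc3)c2n1`: 7680 nM
Compound 2 `C/C(=N\Nc1nc(SCc2ccccc2)nc2c1nnn2Cc1ccccc1)c1ccccc1O`: 850 nM
Compound 3 `C#CCSc1nc(N/N=C/c2c(O)ccc3ccccc23)c2nnn(Cc3ccccc3)c2n1`: 10500 nM

Of the compounds shown here, three have been measured in a functional assay on MGC-803 cells (Homo sapiens) for antiproliferative activity, read by MTT assay, with a stated time of 72 h; on this read-out lower numbers stand for stronger inhibition and higher numbers for weaker inhibition. Compound 1 sits second highest of the three numbers. Its nearest neighbour is compound 3, whose value of 10500 nM is within the scatter of compound 1. The furthest is compound 2, with 850 nM, a gap beyond the scatter; compound 2 differs from compound 1 in more than one place, so nothing can be read from that pair about a single change.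

The unmeasured compound 4 `CCCSc1nc(N/N=C(\C)c2ccccc2O)c2nnn(Cc3ccc(Br)cc3)c2n1` differs from compound 1 in one place: bromo in place of hydroxy on an aromatic carbon, that is, 4-hydroxybenzyl becomes 4-bromobenzyl. Among the measured compounds shown here, no pair of measured compounds isolates this exchange, and the measured set gives no direct guide to its size or direction.

For the measured compounds named here, with no matching step in hand, the step in this assay from compound 1 to compound 4 is expected to be small, a 1.7-fold lower number from compound 1 to compound 4 (0.23 log units; within the scatter), and may well lie within the scatter. For compound 4 the expected value in this assay is 4500 nM, with a range from 1300 nM to 15000 nM.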

Compound 4, half-maximal inhibitory concentration: 11300 nM
Compound 4: middle estimate off by 2.5-fold (0.40 log units), on the low side, within the range that was stated.
By their numbers in this assay, from the lowest: compound 2; then compounds 1, 3 and 4 (each within the scatter of the next).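

In this assay, among the compounds shown here, the exchange of 4-hydroxybenzyl for 4-bromobenzyl gives a 1.5-fold higher number from compound 1 to compound 4 (0.17 log units; within the scatter), the first reading of this change, which no earlier pair of compounds could isolate. At this place, on an aromatic carbon para to a large group, a hydroxy with one hydrogen-bond donor and one acceptor gives way to a bromo with neither, and in this single pair the step stays within the scatter, so the two groups cannot be told apart on this read-out. No measured property of either compound is available to account for this result.

The compounds shown leave open whether an amine or a carboxylic acid at the same place would also stay within the scatter of compound 1, and one pair cannot show whether the position tolerates change in general. Also open, going by these compounds, is what separates these two compounds from compound 2 at 850 nM in this assay, as compound 2 differs from both in more than one place, and whether the exchange would read the same on a compound carrying its benzylthio group in place of the propylthio group.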